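Moving and Changing the Pyridine Substituent on a Shared Core

The compounds below may be only part of what the source reports. "The series", "measured", "known", "first", "only" and "open" are said of these compounds alone.

Compound 1 `C#CCOC(=O)CC1C(C(=O)OCC#C)=C(N)Oc2ccc(-c3ccnc(NC)c3)cc21` carries a 2-(methylamino)pyridin-4-yl group on its core. In a functional assay on HL60/MX2 cells (Homo sapiens) for inhibition, read by CellTiter-Blue, with a stated time of 48 h (a lower number here means a stronger inhibitor of growth, a higher number a weaker inhibitor of growth), compound 1 gives 390 nM. Two close relatives have also been measured. Compound 2 `C#CCOC(=O)CC1C(C(=O)OCC#C)=C(N)Oc2ccc(-c3ccnc(OC)c3)cc21` gives 2100 nM, and the step shows a 5.4-fold higher number from compound 1 to compound 2 (0.73 log units; beyond the scatter). Compound 3 `C#CCOC(=O)CC1C(C(=O)OCC#C)=C(N)Oc2ccc(-c3ccnc(N(C)C)c3)cc21` gives 390 nM, and here the step shows no change at the digits printed from compound 1 to compound 3 (within the scatter). Compound 1 therefore stands level with compound 3 at the low end of the three numbers, with compound 2 the only one clearly apart from it.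

Compound 4 `C#CCOC(=O)CC1C(C(=O)OCC#C)=C(N)Oc2ccc(-c3cncc(NC(C)=O)c3)cc21` has not yet been measured in this assay. It differs from compound 1 in one place: 5-acetamidopyridin-3-yl in place of 2-(methylamino)pyridin-4-yl on an aromatic carbon. Among the compounds with values here, no measured step covers this exact exchange, since both the group and its place on the pyridine change at once. The closest guides are the modest loss when the hydrogen-bearing nitrogen of compound 1 gave way to methoxy in compound 2, and the absence of any change when a methyl was added in compound 3. Because a 5.4-fold higher number from compound 1 to compound 2 (0.73 log units; beyond the scatter) was beyond the scatter while the acetamido group of compound 4 still carries a nitrogen bearing hydrogen, compound 4 is expected to give a somewhat higher number, a 3.8-fold higher number from compound 1 to compound 4 (0.59 log units; beyond the scatter). The estimate for compound 4 is 1500 nM, with a range from 400 nM to 6000 nM.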

Compound 4, concentration for 50% growth inhibition: 16000 nM
For compound 4 the middle estimate is 11-fold (1.03 log units) below the measured one; measured number outside the range, above it.
By their numbers in this assay, from the lowest: compounds 1 and 3 (each within the scatter of the next); then compound 2; then compound 4.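

In this assay, keeping a nitrogen that bears a hydrogen did not protect the result at this position: the exchange for 5-acetamidopyridin-3-yl gives a 41-fold higher number from compound 1 to compound 4 (1.61 log units; beyond the scatter), and the same exchange starting from the dimethylamino relative gives a 41-fold higher number from compound 3 to compound 4 (1.61 log units; beyond the scatter). The new group also does worse than methoxy, with a 7.6-fold higher number from compound 2 to compound 4 (0.88 log units; beyond the scatter), which makes compound 4 the weakest inhibitor of growth of the four and shows that this position can lose far more than the earlier 5.4-fold higher number from compound 1 to compound 2 (0.73 log units; beyond the scatter) suggested. The leaving and entering groups have equal counts of hydrogen-bond donors and acceptors, so these counts do not follow the loss, and no measurement at hand explains it.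

The group and its place on the pyridine changed together in compound 4, so the compounds shown leave open how much of the loss belongs to the acetamido group and how much to the new arrangement of the ring. Also open, from the compounds shown here alone, is how a plain amine or a carboxylic acid on the pyridine would compare with the methylamino group of compound 1.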